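A few compounds are considered here, and "the series" means these few. Any claim that something is new, unique, unknown or untested is made for them only; others in the source may bear on it.

Compound 1 `COc1ccc(C(=O)/C=C/c2cc(-c3cc(OC)c(OC)c(OC)c3)n3nc(-c4ccccc4)cc3n2)cc1` is one of three related compounds tested in a functional assay on DU-145 cells (Homo sapiens) for antiproliferative activity, read by MTT assay, with a stated time of 24 h; on this read-out higher numbers stand for weaker inhibition and lower numbers for stronger inhibition. In this assay compound 1 gives 25200 nM, the second highest of the three numbers. Compound 2 `COc1cc(-c2cc(C(=O)/C=C/c3ccccc3)nc3cc(-c4ccccc4)nn23)cc(OC)c1OC` gives 16300 nM, and compound 3 `COc1cc(-c2cc(/C=C/C(=O)c3ccccc3)nc3cc(-c4ccccc4)nn23)cc(OC)c1OC` gives 34300 nM. The step from compound 1 to compound 2 is a 1.5-fold lower number from compound 1 to compound 2 (0.19 log units; within the scatter), and the step from compound 1 to compound 3 is a 1.4-fold higher number from compound 1 to compound 3 (0.13 log units; within the scatter). Going by the values given here, only the step from compound 2 to compound 3, a 2.1-fold higher number from compound 2 to compound 3 (0.32 log units; beyond the scatter), reaches beyond the scatter. Compound 4 `COc1ccc(C(=O)/C=C/c2cc(-c3ccc(OC)cc3)n3nc(-c4ccccc4)cc3n2)cc1` has not yet been measured in this assay. The change from compound 1 to compound 4 is 4-methoxyphenyl in place of 3,4,5-trimethoxyphenyl on an aromatic carbon. Among the compounds with values here, no measured step alters this particular group. Within the data shown here, the only precedent for removing a methoxy group, a 1.4-fold higher number from compound 1 to compound 3 (0.13 log units; within the scatter), stays within the scatter. Removing two methoxy groups in compound 4 is thus expected to give no change beyond the scatter, or at most a modest weakening, with an expected step of a 1.3-fold higher number from compound 1 to compound 4 (0.10 log units; within the scatter). Compound 4 is therefore estimated at 32000 nM, within a range from 13000 nM to 80000 nM.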

Compound 4, half-maximal inhibitory concentration: 8500 nM
The estimate for compound 4 lay 3.8-fold (0.58 log units) above the measured number; the measured number lies below the stated range.
By their numbers in this assay, from the lowest: compounds 4, 2, 1 and 3 (each within the scatter of the next, the first and the last beyond it).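

Placing 4-methoxyphenyl in place of 3,4,5-trimethoxyphenyl on the aromatic carbon next to the ring nitrogen gives, in this assay, a 3.0-fold lower number from compound 1 to compound 4 (0.47 log units; beyond the scatter). Going by these compounds alone, this is the first measured change to this group, and it shows that the position can move the number beyond the scatter, whereas removing the methoxy group from the other aryl ring, a 1.4-fold higher number from compound 1 to compound 3 (0.13 log units; within the scatter), did not. No measurement given here accounts for this drop.

As far as these compounds go, since two methoxy groups leave together, this single pair cannot show whether one of them or both matter, and it remains open whether the same change would lower the number with the linkers of compound 2 or compound 3. From the compounds shown here alone, how a 4-hydroxyphenyl, 4-aminophenyl or 4-chlorophenyl group would fare at this position is also open.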